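A few compounds are considered here, and "the series" means these few. Any claim that something is new, unique, unknown or untested is made for them only; others in the source may bear on it.

Measured in a functional assay on MIA PaCa-2 cells (Homo sapiens) for inhibition, read by MTT assay, with a stated time of 48 h, tested at 10 uM; on this read-out lower numbers stand for less inhibition of growth and higher numbers for more inhibition of growth at the one concentration tested:
- compound 1 `Cc1cc(=O)c2c(O)c(CN3CCC(N4CCCCC4)CC3)c(O)c([C@H]3CCN(C)C[C@H]3O)c2o1`: 23%
- compound 2 `Cc1cc(=O)c2c(O)c(CN3CCN(C(=O)OC(C)(C)C)CC3)c(O)c([C@H]3CCN(C)C[C@H]3O)c2o1`: 6%
- compound 3 `CN1CC[C@H](c2c(O)cc(O)c3c(=O)cc(/C=C/c4ccc(Cl)cc4)oc23)[C@H](O)C1`: 88%

Compound 3 stands highest of the three, beyond the scatter from both compound 1 and compound 2. It alone carries the 2-(4-chlorophenyl)ethenyl group. Within the data shown here, no measured pair differs in one place, so the data give no direct size for a single change.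

Compound 4 `CN1CC[C@H](c2c(O)cc(O)c3c(=O)cc(/C=C/c4cccc(F)c4)oc23)[C@H](O)C1` differs from compound 3 on a double-bonded chain carbon bound to a double-bonded chain carbon: 3-fluorophenyl in place of 4-chlorophenyl on a double-bonded chain carbon bound to a double-bonded chain carbon. With the ethenyl chain kept, a result close to compound 3 at 88% is expected. A modest fall is expected, estimated as a number 10 percentage points lower from compound 3 to compound 4 (within the scatter). The estimate for compound 4 is 78%, expected within 55% to 92%.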

Compound 4, percent growth inhibition at one concentration: 67%
The estimate for compound 4 lay 11 percentage points above the measured number, within the range that was stated.
By their numbers in this assay, from the lowest: compound 2; then compound 1; then compound 4; then compound 3.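

Replacing 4-chlorophenyl with 3-fluorophenyl on the ethenyl chain gives a number 21 percentage points lower from compound 3 to compound 4 (beyond the scatter) in this assay, so growth inhibition at this position depends on the aryl group it carries. This single step changes both the halogen and its place on the phenyl ring, and the two changes cannot be separated here. No measurement shown gives a cause for the step.

Open, from the compounds shown here alone, is how 3-chlorophenyl or 4-fluorophenyl would read at this position, which would separate the two changes. Also open, going by these compounds, is whether a phenyl ring bearing an amine or a carboxylic acid would be tolerated on the chain.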